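A few compounds are considered here, and "the series" means these few. Any claim that something is new, unique, unknown or untested is made for them only; others in the source may bear on it.

Series notes: three hydroxamic acids sharing the same core have been measured so far. Compound 1 `O=C(/C=C/c1ccc(/C=C/C(=O)c2cc(Cl)ccc2Cl)o1)NO` gives 4120 nM in a functional assay on HCT-116 cells (Homo sapiens) for antiproliferative activity, read by MTT assay, with a stated time of 48 h; a lower number here means a stronger inhibitor, a higher number a weaker inhibitor. Compound 2 `O=C(/C=C/c1ccc(/C=C/C(=O)c2ccc3ccccc3c2)o1)NO` gives 2220 nM in this assay, and compound 3 `O=C(/C=C/c1ccc(/C=C/C(=O)c2ccc(Cl)cc2)o1)NO` gives 2010 nM. Compound 3 holds the lowest of the three numbers, but its gap to compound 2 lies within the scatter, so no order between those two can be read; only the gap to compound 1 lies beyond the scatter.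

The next compound in line is compound 4 `Cc1ccc(C(=O)/C=C/c2ccc(/C=C/C(=O)NO)o2)cc1`, not yet measured in this assay. It differs from compound 3 in one place: methyl in place of chloro on an aromatic carbon. The change swaps one single heavy atom for another on an aromatic carbon of the six-membered aromatic ring of carbon only, para to a large group, with no change in ring count, donors or acceptors.

Going by the values given here, no measured pair carries a comparable change, so there is nothing to anchor the direction. The expectation is a step from compound 3 to compound 4 of a 1.2-fold higher number from compound 3 to compound 4 (0.09 log units; within the scatter), that is, none beyond the scatter. For compound 4 the estimated value in this assay is 2500 nM, with a range from 1200 nM to 5200 nM.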

Compound 4, half-maximal inhibitory concentration: 540 nM
Estimate against measurement, compound 4: 4.6-fold (0.67 log units) above, and the stated range ends above it.
By their numbers in this assay, from the lowest: compound 4; then compounds 3, 2 and 1 (each within the scatter of the next, the first and the last beyond it).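

In this assay the change from 4-chlorophenyl to 4-methylphenyl brings a 3.7-fold lower number from compound 3 to compound 4 (0.57 log units; beyond the scatter) and so gives the series its first single-change step, one that lies beyond the scatter. The aromatic carbon para to a large group therefore responds to the exchange of one heavy atom for another, even with ring count, donors and acceptors unchanged. Nothing available bears on why methyl gives the lower number here.

Going by these compounds, whether this step is particular to methyl remains open, as an ethyl, a methoxy or an amine on the same carbon would show how far the trend extends. Also open, on these data alone, is whether methyl in place of chloro brings a step of similar size on the 2,5-dichlorophenyl ring of compound 1.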